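Adding a ring chloro to compound 1

This account rests on a few compounds, and the source may have more. Where it says the series, first, only, none or still open, it means among the compounds named here.

In an ADME assay (liver) for metabolic stability, with Liver microsome (Rattus norvegicus) as the target, using microsomes (a lower number here means slower removal, a higher number faster removal of the compound), compound 1 `Cc1cc2c(c(Oc3cccc(NS(=O)(=O)c4ccc(Cl)cc4)c3)n1)C(=O)N(C(C)C)C2=O` gives 250 mL.min-1.g-1. Compound 3 `Cc1cc2c(c(Oc3ccc(C)c(NS(=O)(=O)c4ccc(Cl)cc4)c3)n1)C(=O)N(C(C)C)C2=O` gives 131 mL.min-1.g-1, which is a 1.9-fold lower number from compound 1 to compound 3 (0.28 log units; within the scatter). Compound 2 `Cc1cc2c(c(Oc3cccc(NC(=O)c4ccc(Cl)cc4)c3)n1)C(=O)N(C(C)C)C2=O` gives 40 mL.min-1.g-1, which is a 6.3-fold lower number from compound 1 to compound 2 (0.80 log units; beyond the scatter). Compound 1 therefore stands clearly apart from compound 2 but not from compound 3.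

Compound 4 `Cc1cc2c(c(Oc3cc(NS(=O)(=O)c4ccc(Cl)cc4)ccc3Cl)n1)C(=O)N(C(C)C)C2=O` differs from compound 1 by chloro in place of hydrogen on an aromatic carbon, ortho to a large group and para to a ((4-chlorophenyl)sulfonyl)amino group. Among the compounds with values here, the series holds no measured chloro step on this ring. The step to compound 2 replaces the (4-chlorophenyl)sulfonyl group, which compound 4 keeps, so it offers little guidance. Within the data shown here, the closest precedent is compound 3, with methyl in place of hydrogen on an aromatic carbon and a 1.9-fold lower number from compound 1 to compound 3 (0.28 log units; within the scatter). A small step within the scatter, leaning towards a lower number, is therefore expected. The expected change is a 1.5-fold lower number from compound 1 to compound 4 (0.17 log units; within the scatter). The estimated value for compound 4 is 170 mL.min-1.g-1, with an expected range of 80 mL.min-1.g-1 to 350 mL.min-1.g-1.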

Compound 4, intrinsic clearance in microsomes: 29 mL.min-1.g-1
Compound 4: middle estimate off by 5.9-fold (0.77 log units), on the high side; measured number outside the range, below it.
By their numbers in this assay, from the lowest: compounds 4 and 2 (each within the scatter of the next); then compounds 3 and 1 (each within the scatter of the next).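

In this assay, chloro in place of hydrogen on an aromatic carbon, ortho to a large group and para to a ((4-chlorophenyl)sulfonyl)amino group, gives an 8.6-fold lower number from compound 1 to compound 4 (0.94 log units; beyond the scatter) and keeps the (4-chlorophenyl)sulfonyl group. Among the earlier steps, only the carbonyl replacement, a 6.3-fold lower number from compound 1 to compound 2 (0.80 log units; beyond the scatter), lay beyond the scatter, whereas the methyl on another carbon of this ring gave a 1.9-fold lower number from compound 1 to compound 3 (0.28 log units; within the scatter), so a single heavy atom on this ring can now be seen to produce a step beyond the scatter. No measurement shown here explains the size of this step.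

The compounds shown leave open whether fluoro, methoxy or an amine at this position would give a similar step. They also leave open whether chloro here would move the number on the (4-chlorophenyl)carbonyl compound 2, or only on the sulfonyl compounds.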